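This account rests on a few compounds, and the source may have more. Where it says the series, first, only, none or still open, it means among the compounds named here.

Compound 1, `CCCCCCCCCCC(C)OC(=O)CC(=O)Nc1c(C(C)C)cccc1C(C)C`, is tested in an assay on microsomes from intestine for inhibition of acyl-CoA:cholesterol acyltransferase (Oryctolagus cuniculus) (a higher number here means a weaker inhibitor, a lower number a stronger inhibitor), and gives 6 nM, the lowest of the three numbers measured. Compound 2, `CC(C)c1cccc(C(C)C)c1OC(=O)CC(=O)Nc1c(N(C)C)cccc1N(C)C`, gives 71 nM in this assay, and compound 3, `COc1cc(OC)c(NC(=O)CC(=O)Oc2c(C(C)C)cccc2C(C)C)c(OC)c1`, gives 1000 nM; both of these steps up from compound 1 lie beyond the usual scatter, so compound 1 is the strongest inhibitor among the three. Compound 4, `CCOC(=O)CC(=O)Nc1c(C(C)C)cccc1C(C)C`, has not yet been measured. It differs from compound 1 in one place: hydrogen in place of decyl on a saturated chain carbon bound to an oxygen next to a carbonyl group and a saturated chain carbon. For the measured compounds named here, no measured pair shows this change, so its effect can only be estimated. The step from compound 1 to compound 4 is expected to be a clear rise in the number, well beyond the scatter, amounting to a 250-fold higher number from compound 1 to compound 4 (2.40 log units; beyond the scatter). Compound 4 is therefore expected to give about 1500 nM in this assay, likely between 200 nM and 15000 nM.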

Compound 4, half-maximal inhibitory concentration: 1800 nM
Compound 4: middle estimate off by 1.2-fold (0.08 log units), on the low side, within the range that was stated.
By their numbers in this assay, from the lowest: compound 1; then compound 2; then compounds 3 and 4 (each within the scatter of the next).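

For the compounds shown here, with hydrogen in place of decyl on this saturated chain carbon, this assay shows a 300-fold higher number from compound 1 to compound 4 (2.48 log units; beyond the scatter), the first direct reading of this position. For this pair, the decyl group accounts for a very large part of the low number of compound 1. No measurement shown explains why the step is so large. A single pair cannot show whether the number rises gradually as the chain shortens. On these data alone, it also remains open whether butyl, hexyl, a phenyl ring or an amine on this carbon would keep the low number of compound 1.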